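The compounds below may be only part of what the source reports. "The series", "measured", "known", "first", "only" and "open" are said of these compounds alone.

Measured in a functional assay on HL-60 cells (Homo sapiens) for antiproliferative activity, with a stated time of 72 h; on this read-out lower numbers stand for stronger inhibition and higher numbers for weaker inhibition:

compound 1 `OC[C@H]1O[C@@H](n2cnc3c(NCc4ccc(Cl)cc4)ncnc32)[C@H](O)[C@@H]1O` gives 1700 nM
compound 2 `OC[C@H]1O[C@@H](n2cnc3c(NCc4ccccc4Br)ncnc32)[C@H](O)[C@@H]1O` gives 6600 nM
compound 3 `OC[C@H]1O[C@@H](n2cnc3c(NCc4ccc(Br)cc4)ncnc32)[C@H](O)[C@@H]1O` gives 47400 nM

Compound 3 has the highest number of the three, which makes it the weakest inhibitor here, and its steps to both others lie beyond the scatter. Compound 4 `OC[C@H]1O[C@@H](n2cnc3c(NCc4ccc(Cl)cc4Cl)ncnc32)[C@H](O)[C@@H]1O` has not yet been measured. It differs from compound 3 by 2,4-dichlorophenyl in place of 4-bromophenyl on a saturated chain carbon bound to a nitrogen on an aromatic ring in all.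

For the measured compounds named here, three measured steps bear on this change. The largest is a 28-fold higher number from compound 1 to compound 3 (1.45 log units; beyond the scatter) for bromo in place of chloro on an aromatic carbon. Next comes a 7.2-fold higher number from compound 2 to compound 3 (0.86 log units; beyond the scatter) for 4-bromophenyl in place of 2-bromophenyl. The smallest is a 3.9-fold higher number from compound 1 to compound 2 (0.59 log units; beyond the scatter) between the two better compounds. Going by the values given here, compound 4 resembles compound 1 in carrying chloro and compound 2 in its substitution pattern, but no measured compound carries a 2,4-dichlorophenyl group, so how these features combine is unknown. A large step to a lower number, meaning stronger inhibition, is therefore expected in this assay for this change. The expected change is a 12-fold lower number from compound 3 to compound 4 (1.07 log units; beyond the scatter) on this estimate. The estimated value for compound 4 is 4000 nM within an expected range of 1000 nM to 16000 nM for now.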

Compound 4, half-maximal inhibitory concentration: 96300 nM
Estimate against measurement, compound 4: 24-fold (1.38 log units) below, and the stated range ends below it.
By their numbers in this assay, from the lowest: compound 1; then compound 2; then compound 3; then compound 4.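

In this assay the 2,4-dichlorophenyl group gives the weakest inhibitor of the four compounds, and the clearest sign of this is a 57-fold higher number from compound 1 to compound 4 (1.75 log units; beyond the scatter) for chloro in place of hydrogen on an aromatic carbon. That is the largest step among the compounds shown, so a single added chloro on the phenyl ring of the strongest compound is enough to lose most of its activity. The other new steps point the same way, with a 15-fold higher number from compound 2 to compound 4 (1.16 log units; beyond the scatter) as a large loss and a 2.0-fold higher number from compound 3 to compound 4 (0.31 log units; beyond the scatter) as a modest one, which means that at this position on the saturated chain carbon bound to a nitrogen on an aromatic ring, adding halogen to the phenyl ring brought no gain in any comparison shown here.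

The compounds shown leave open how the phenyl ring would respond to something other than a halogen, such as an amine or a carboxylic acid, and how a longer chain between the ring and the shared core would read in this assay. Nothing available here explains why the added chloro weakens inhibition so sharply.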